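Acetyl for Dimethylamino at the Far End of the Molecule

The compounds below may be only part of what the source reports. "The series", "measured", "known", "first", "only" and "open" are said of these compounds alone.

Measured compounds:
compound 1, `COc1cc(C)cc(-c2c(-c3ccnc(-c4ccc(N(C)C)cc4)c3)cnn2CC#N)c1` — 95%
compound 2, `Cc1cc(O)cc(-c2nn(CC#N)cc2-c2ccnc(-c3ccc(Oc4ccccc4)cc3)c2)c1` — 97%

Of the compounds shown here, two sharing one core have been measured so far. In a functional assay on U-251 cells (Homo sapiens) for cytotoxicity, read by sulforhodamine B assay, with a stated time of 48 h, tested at 0.001 uM (a higher number here means a weaker effect of the compound at the concentration tested, a lower number a stronger effect), compound 1 gives 95%. In this assay compound 2 gives 97%. The two numbers lie within the usual scatter of each other, so neither compound stands apart from the other on this read-out; both leave the cells largely unaffected at the concentration tested.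

Compound 3, `COc1cc(C)cc(-c2c(-c3ccnc(-c4ccc(C(C)=O)cc4)c3)cnn2CC#N)c1`, is the next compound to be measured. It differs from compound 1 in one place: acetyl in place of dimethylamino on an aromatic carbon. For the measured compounds named here, no pair of measured compounds differing in a single place is available, so there is no comparable step to rest on. Given that compound 1 sits near the top of the scale in this assay and that compound 2, carrying a different group at the same end of the molecule, does the same, the step of no change at the digits printed from compound 1 to compound 3 (within the scatter) is expected to stay within the scatter, with no direction to it. Compound 3 is therefore estimated at 95%, in the range 85% to 104%.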

Compound 3, a percentage reported as activity, at one concentration (the size of the read-out at that concentration, not a potency): 104%
For compound 3 the middle estimate is 9 percentage points below the measured one; the range from low to high includes it.
By their numbers in this assay, from the lowest: compounds 1, 2 and 3 (each within the scatter of the next).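

For the compounds shown here, this is the first comparison between compounds that differ in only one place: in this assay, exchanging 4-(dimethylamino)phenyl for 4-acetylphenyl gives a number 9 percentage points higher from compound 1 to compound 3 (within the scatter), so this read-out does not separate the two groups at the concentration tested. The exchange replaces a nitrogen-bearing group with a carbonyl-bearing one of the same heavy-atom count, on an aromatic carbon para to a large group, and this change of atoms at this position produces no step beyond the scatter. No accompanying measurement offers an explanation for this result.

From the compounds shown here alone, how a carboxylic acid, a primary amine or a longer chain at the same place, with the rest of compound 1 kept, would read in this assay stays open. Going by these compounds, it also remains open whether dimethylamino and acetyl would still be indistinguishable at a higher concentration, where the cells might respond more strongly and a difference between the groups could appear.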